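Heteroaryl exchange at the shared core: compound 3

The source may hold more compounds than are shown below. What is called first, only, known or untested is meant among the compounds shown, and "the series" means these compounds.

In an assay on blood for inhibition of C-X-C chemokine receptor type 3 (Homo sapiens), with a stated time of 30 min (a higher number here means a weaker inhibitor, a lower number a stronger inhibitor), compound 2 `CCCc1ncc(-c2nc(C(F)(F)F)sc2N2CCN(C(=O)Cn3nc(C)nc3C)[C@H](C)C2)cn1` gives 367 nM and stands as the lower of the two numbers shown. Compound 1 `Cc1ncc(-c2nc(C(F)(F)F)sc2N2CCN(C(=O)Cn3nc(C)nc3C)[C@H](C)C2)cn1` gives 610 nM in this assay. For the measured compounds named here, the only measured step, a 1.7-fold lower number from compound 1 to compound 2 (0.22 log units; within the scatter), does not separate the two compounds. Compound 3 `CCOc1ccc(-c2nc(C(F)(F)F)sc2N2CCN(C(=O)Cn3nc(C)nc3C)[C@H](C)C2)cn1` carries 6-ethoxypyridin-3-yl in place of 2-propylpyrimidin-5-yl on an aromatic carbon. Going by the values given here, no measured step exchanges the whole aromatic group; the ethyl-for-hydrogen step bears on this change only loosely and was small. Hence no step beyond the scatter is expected in this assay. For compound 3 the estimate is 420 nM, range 150 nM to 1200 nM, an expected step of a 1.1-fold higher number from compound 2 to compound 3 (0.06 log units; within the scatter).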

Compound 3, half-maximal inhibitory concentration: 887 nM
Compound 3: the middle estimate sits 2.1-fold (0.32 log units) below what was measured, within the range that was stated.
By their numbers in this assay, from the lowest: compounds 2, 1 and 3 (each within the scatter of the next, the first and the last beyond it).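

In this assay, for the compounds shown here, replacing the whole aromatic group at this position gives a 2.4-fold higher number from compound 2 to compound 3 (0.38 log units; beyond the scatter) as the first step to pass the scatter, though only modestly. Measured against 2-methylpyrimidin-5-yl, the same entering group gives a 1.5-fold higher number from compound 1 to compound 3 (0.16 log units; within the scatter) and no separation, so the reading depends on which pyrimidine serves as reference. Nothing available bears on the cause of the shift. The exchange alters the ring and its chain together, and the compounds shown do not separate these two changes. On these data alone, how 2-ethoxypyrimidin-5-yl or 6-propylpyridin-3-yl would read at this position remains open.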